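Will a Carboxy Swap Leave Compound 1 Untouched?

The compounds below may be only part of what the source reports. "The series", "measured", "known", "first", "only" and "open" are said of these compounds alone.

In an ADME assay on J774 cells (Mus musculus) for cytotoxicity (a lower number here means that less compound is needed, a higher number that more compound is needed for the effect), compound 1 (`CCCCc1cc2c(=O)c(C#N)c[nH]c2cc1OCCOc1ccccc1`) gives > 20000 nM, which is a limit of the assay and not a number. Its place among the results is the limit of > 20000 nM in this assay, at which 1 of the 3 values shown sits.

Compound 4 (`CCCCc1cc2c(=O)c(C(=O)O)c[nH]c2cc1OCCOc1ccccc1`) carries carboxy in place of cyano on an aromatic carbon of the core: carboxy in place of cyano on an aromatic carbon. Its result is not yet known.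

Two relatives have numbers: compound 2 (`COC(=O)c1c[nH]c2ccc(OCCc3ccccc3)cc2c1=O`) gives 2200 nM, and compound 3 (`COC(=O)c1c[nH]c2ccc(OCCCc3ccccc3)cc2c1=O`) gives 17100 nM. Among the compounds with values here, the only measured step, a 7.8-fold higher number from compound 2 to compound 3 (0.89 log units; beyond the scatter), has benzyl in place of phenyl on a saturated chain. It shows that a change elsewhere in the molecule can move this assay, but it says nothing about swapping cyano for carboxy.

Within the data shown here, no measured step touches that place, so the expectation rests on the limit of compound 1 alone. No clear step beyond the scatter is expected, and the estimated change is a step that the limit leaves unreadable from compound 1 to compound 4. For compound 4 the expected value is 25000 nM, with an estimated range of 9000 nM to 70000 nM.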

Compound 4, half-maximal effective concentration: > 20000 nM
Compound 4: no number, only a limit; the forecaster's own chance of this, stated with the estimate: 75%; the middle value lies beyond the limit too.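

In this assay compound 4 gives > 20000 nM, which is a limit and not a number. Within the data shown here, compound 1 gives > 20000 nM, also a limit, and no step between these two compounds can be read. The compounds shown leave open whether carboxy in place of cyano on an aromatic carbon moves this result at all.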